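The compounds below may be only part of what the source reports. "The series", "measured", "known", "first", "only" and "open" are said of these compounds alone.

Compound 1 `C=CCn1c(=O)/c(=C\c2ccccc2Cl)[nH]c(=O)/c1=C\c1ccccc1OC`: 5100 nM
Compound 2 `C=CCn1c(=O)/c(=C\c2ccc(Cl)c(Cl)c2)[nH]c(=O)/c1=C\c1ccccc1OC`: "not active" (no number reported)

Of the compounds shown here, two sharing one core have been tested in a functional assay on HeLa cells (Homo sapiens) for cytotoxicity, read by CCK-8 assay, with a stated time of 72 h; on this read-out higher numbers stand for weaker inhibition and lower numbers for stronger inhibition. Compound 1 is the only one with a numerical result, giving 5100 nM; compound 2 is reported in this assay as "not active" (no number reported), with no number attached, so it stands apart from compound 1 only in having fallen outside the measurable window. Among the compounds with values here, no pair of measured compounds differs in a single place, so no step size can be read off directly.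

Compound 3 `C=CCn1c(=O)/c(=C\c2ccc(F)c(Br)c2)[nH]c(=O)/c1=C\c1ccccc1OC` has not been measured. It differs from compound 1 in one place: 3-bromo-4-fluorophenyl in place of 2-chlorophenyl on a double-bonded chain carbon bound to an aromatic carbon. Since compound 1 is the only numbered anchor, and compound 2 shows that a change of the halogen pattern on that ring can take the activity out of range, a step in the weaker direction, of a size beyond the usual scatter, is expected for compound 3, a 2.9-fold higher number from compound 1 to compound 3 (0.47 log units; beyond the scatter). Compound 3 is estimated in this assay at 15000 nM, with a range from 5000 nM to 50000 nM, and a real chance that, like compound 2, only an inactive call is returned.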

Compound 3, half-maximal inhibitory concentration: "not active" (no number reported)
Compound 3 has no reported number here; no gap can be computed for the estimate.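

Within the data shown here, compound 3 is reported in this assay as not active, without a number, so no step from compound 1 can be read. The compounds shown leave open how far compound 2 and compound 3 lie from compound 1 , which stands at 5100 nM as the only number. No measured evidence bears on this result.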